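The source may report more compounds than this note shows. Statements on the series, on what has been measured and on what is new or still open speak of the compounds shown alone.

In an ADME assay (liver) for metabolic stability, with Liver microsome (Homo sapiens) as the target, using microsomes and NADPH, with a stated time of 30 min, tested at 1 uM (a lower number here means slower removal, a higher number faster removal of the compound), compound 3 `Nc1ccc(S(=O)(=O)N2CCN(c3ncc(C(O)(C(F)(F)F)C(F)(F)F)cc3-c3ccc4sccc4c3)CC2)cn1`, which carries 1-benzothiophen-5-yl, gives 48 mL.min-1.g-1. Compound 2 `CS(=O)(=O)c1ccc(-c2cc(C(O)(C(F)(F)F)C(F)(F)F)cnc2N2CCN(S(=O)(=O)c3ccc(N)nc3)CC2)cc1`, which carries 4-(methylsulfonyl)phenyl instead, gives 32 mL.min-1.g-1, and these two values lie within the scatter of each other. Compound 1 `Nc1ccc(S(=O)(=O)N2CCN(c3ncc(C(O)(C(F)(F)F)C(F)(F)F)cc3C#CCCO)CC2)cn1`, which carries 4-hydroxybut-1-yn-1-yl, reads < 14 mL.min-1.g-1, and this is a limit of the assay, not a number.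

Compound 4 `Nc1ccc(S(=O)(=O)N2CCN(c3ncc(C(O)(C(F)(F)F)C(F)(F)F)cc3-c3ccc4c(c3)CC(=O)N4)CC2)cn1` has not yet been measured. Its difference from compound 3 is a group of 10 heavy atoms (8 carbon, 1 nitrogen, 1 oxygen; one five-membered non-aromatic ring with 1 hetero atom, one six-membered aromatic ring of carbon only) in place of a group of 9 heavy atoms (8 carbon, 1 sulfur; one five-membered aromatic ring with 1 hetero atom, one six-membered aromatic ring of carbon only), on an aromatic carbon, and the change sits on an aromatic carbon, ortho to a large group.

Two measured steps replace 4-hydroxybut-1-yn-1-yl with a ring-bearing group, an at least 2.2-fold higher number from compound 1 to compound 2 (0.35 log units; beyond the scatter) and an at least 3.4-fold higher number from compound 1 to compound 3 (0.53 log units; beyond the scatter), and both go beyond the scatter. Neither matches the present change, since compound 4 keeps a group with a six-membered aromatic ring at this place. The closer precedent is the exchange of one such group for another, a 1.5-fold higher number from compound 2 to compound 3 (0.18 log units; within the scatter), which stays within the scatter. On that precedent, no step beyond the scatter is expected in this assay, though the direction may lean towards a lower number. The expected change is a 1.6-fold lower number from compound 3 to compound 4 (0.20 log units; within the scatter). For compound 4 the estimated value is 30 mL.min-1.g-1, with an expected range from 15 mL.min-1.g-1 to 60 mL.min-1.g-1.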

Compound 4, intrinsic clearance in microsomes: < 14 mL.min-1.g-1
Compound 4: a limit, no number; the forecaster's own chance of this, stated with the estimate: 15%; middle value at least 2.1-fold (0.33 log units) from the limit.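

In this assay, the exchange of one ring-bearing group for another at this place had stayed within the scatter for compound 2 and compound 3, but the new group, with its five-membered non-aromatic ring, moves the reading beyond the scatter in both comparisons: an at least 3.4-fold lower number from compound 3 to compound 4 (0.53 log units; beyond the scatter), and an at least 2.2-fold lower number from compound 2 to compound 4 (0.35 log units; beyond the scatter). The place therefore tells these ring-bearing groups apart, and a six-membered aromatic ring here does not by itself go with the higher readings, since compound 4 gives < 14 mL.min-1.g-1, which is a limit of the assay and not a number. The step between compound 1 and compound 4 cannot be read, because both compounds stand at the same limit: the limit of < 14 mL.min-1.g-1 in this assay, at which 2 of the 4 values shown sit.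

The compounds shown do not separate the carbonyl from the amide hydrogen of the entering group, so it stays open which of them, if either, goes with the lower reading. Whether a simple amine or a carboxylic acid on the six-membered aromatic ring would also reach the limit in this assay is left open as well.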